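Fluoro for Methoxy on the Aryl Sulfanyl Arm

A few compounds are considered here, and "the series" means these few. Any claim that something is new, unique, unknown or untested is made for them only; others in the source may bear on it.

The series is read in a functional assay on A549 cells (Homo sapiens) for inhibition, read by sulforhodamine B assay, with a stated time of 48 h; on this read-out higher numbers stand for weaker inhibition of growth and lower numbers for stronger inhibition of growth. Compound 1 `CCOC(=O)[C@H](CCC(=O)O)NC(=O)c1ccc(Oc2nc3cc(N)cc(N)c3nc2-c2ccccc2)cc1` carries the shared core with an ester-bearing amide side chain. In this assay compound 1 gives < 100000 nM, which is a limit of the assay and not a number. Compound 2 `COc1ccc(Sc2nc3cc(N)cc(N)c3nc2-c2ccccc2)cc1` carries the (4-methoxyphenyl)sulfanyl group on the same core. In this assay compound 2 gives < 100000 nM, again a limit rather than a number. Compound 2 thus sits at the limit of < 100000 nM in this assay, at which 2 of the 2 values shown sit. Among the measured compounds shown here, no measured step separates compound 2 from compound 1; the two values show only that both rest at the same limit.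

Compound 3 `Nc1cc(N)c2nc(-c3ccccc3)c(Sc3ccc(F)cc3)nc2c1` differs from compound 2 by fluoro in place of methoxy on an aromatic carbon. For the measured compounds named here, no step between measured compounds covers this change, and the values behind it are limits only. No shift beyond the usual scatter is expected, so the step from compound 2 to compound 3 is estimated at a step that the limit leaves unreadable from compound 2 to compound 3. Compound 3 is expected at 30000 nM, within 6000 nM to 100000 nM, and may well again be returned only as a limit.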

Compound 3, concentration for total growth inhibition: 30900 nM
Beside the measured number, compound 3's estimate is 1.0-fold (0.01 log units) below it; low and high end bracket the measured number.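

No step from compound 2 to compound 3 can be read in this assay, because compound 2 stands only at a limit of the assay and not at a number: the limit of < 100000 nM in this assay, at which 2 of the 3 values shown sit.

The compounds shown leave open how fluoro and methoxy compare on this aryl sulfanyl arm, and where compound 1 and compound 2 lie beneath their limits.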